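A Small Addition to a Weak Compound

A few compounds are considered here, and "the series" means these few. Any claim that something is new, unique, unknown or untested is made for them only; others in the source may bear on it.

Compound 1 `COc1cc(NC(C)CCCNC(=O)NN)c2ncccc2c1` is the starting point here, tested in a functional assay on NCI-H460 cells (Homo sapiens) for inhibition, read by MTT assay, with a stated time of 4 days; on this read-out higher numbers stand for weaker inhibition and lower numbers for stronger inhibition. In that test compound 1 gives > 100000 nM, which is a limit of the assay and not a number. This places it at the limit of > 100000 nM in this assay, at which 1 of the 2 values shown sits. Compound 2 `COc1cc(NC(C)CCCNC(=O)NNC(=O)NCCCC(C)Nc2cc(OC)cc3cccnc23)c2ncccc2c1` holds the core of compound 1 twice. In the same test compound 2 gives 94000 nM. Neither result shows strong inhibition.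

Compound 3 `COc1cc(NC(C)CCCNC(=O)NNC(=O)NCCCO)c2ncccc2c1` keeps the core of compound 1 and changes one place: (3-hydroxypropyl)carbamoyl in place of hydrogen on an amine nitrogen. In words, a (3-hydroxypropyl)carbamoyl stands in place of hydrogen on an amine nitrogen.

Compound 2 also carries a carbamoyl group on that amine nitrogen, and its 94000 nM still marks weak inhibition. On that basis, only a small step towards stronger inhibition is expected in this assay, and the result could again be only a limit. The expected change is an at least 1.1-fold lower number from compound 1 to compound 3 (0.04 log units; that floor lies within the scatter). For compound 3 the estimated value is 90000 nM, with an expected range from 40000 nM to 150000 nM.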

Compound 3, half-maximal inhibitory concentration: > 100000 nM
Compound 3: a limit, no number (the forecaster's own chance of this, stated with the estimate: 50%); at least 1.1-fold (0.04 log units) between middle value and limit.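

In this assay compound 3 gives > 100000 nM, which is a limit of the assay and not a number. Within the data shown here, compound 1 also stands at a limit, so no step from compound 1 to compound 3 can be read. The compounds shown leave open whether (3-hydroxypropyl)carbamoyl in place of hydrogen on that amine nitrogen changes inhibition at all.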